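Homologation of the branched alkyl on the core

The source may report more compounds than this note shows. Statements on the series, on what has been measured and on what is new or still open speak of the compounds shown alone.

Compound 3 `CC(C)(C)Cc1cnc(CCc2ccc(-c3ccccc3C(=O)O)cc2)[nH]1` gives 6.3 nM in an in vitro functional assay on cells for agonist activity at Bombesin receptor subtype-3 (Mus musculus), read by luminescence and calcium flux (a lower number here means that less compound is needed, a higher number that more compound is needed for the effect), the lowest of the three numbers in hand. Compound 1 `O=C(O)c1ccccc1-c1ccc(CCc2ncc(CC3CCCCC3)[nH]2)cc1` gives 7.3 nM in this assay, and the step of a 1.2-fold lower number from compound 1 to compound 3 (0.06 log units; within the scatter) is within the scatter, so compounds 1 and 3 are not separated. Compound 2 `N#Cc1ccc(Cc2cnc(CCc3ccc(-c4ccccc4C(=O)O)cc3)[nH]2)cc1` gives 723 nM in this assay, and the steps of a 99-fold higher number from compound 1 to compound 2 (2.00 log units; beyond the scatter) and a 110-fold lower number from compound 2 to compound 3 (2.06 log units; beyond the scatter) are both large, so compound 2 stands well apart.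

Compound 4 `CC(C)(C)CCc1cnc(CCc2ccc(-c3ccccc3C(=O)O)cc2)[nH]1` is not yet measured. It differs from compound 3 as follows: neopentyl in place of tert-butyl on a saturated chain carbon bound to an aromatic carbon. The change keeps a saturated, branched alkyl at this place and only lengthens the chain. The step that bears on it is the exchange of cyclohexyl for tert-butyl, a 1.2-fold lower number from compound 1 to compound 3 (0.06 log units; within the scatter), which was within the scatter; the large steps to compound 2 involve an aromatic group with a nitrile and do not resemble this change. A step no larger than the scatter is therefore expected, a 1.3-fold higher number from compound 3 to compound 4 (0.10 log units; within the scatter). Compound 4 is estimated at 8 nM in this assay, with a range from 3 nM to 25 nM.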

Compound 4, half-maximal effective concentration: 6.2 nM
The estimate for compound 4 lay 1.3-fold (0.11 log units) above the measured number; measured number inside the range.
By their numbers in this assay, from the lowest: compounds 4, 3 and 1 (each within the scatter of the next); then compound 2.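

Lengthening tert-butyl to neopentyl leaves the number in this assay unchanged within the scatter (a 1.0-fold lower number from compound 3 to compound 4 (0.01 log units; within the scatter)), and neopentyl is likewise not separated from cyclohexyl (a 1.2-fold lower number from compound 1 to compound 4 (0.07 log units; within the scatter)). Among the compounds shown, this place on a saturated chain carbon bound to an aromatic carbon therefore accepts all three saturated groups without a measurable difference, while compound 2, with 4-cyanophenyl, goes against this and stands far apart (a 120-fold lower number from compound 2 to compound 4 (2.07 log units; beyond the scatter)). No measurement at hand explains either the flat response among the saturated groups or the large gap to compound 2.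

The compounds shown leave open how far the chain can grow beyond neopentyl, for example to 4,4-dimethylpentyl, and whether an amine at the chain end would be tolerated. They also do not separate the contribution of the nitrile from that of the aromatic ring, which an unsubstituted phenyl would address.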